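From bromo to methoxy on the shared core

The compounds below may be only part of what the source reports. "The series", "measured", "known", "first", "only" and "open" are said of these compounds alone.

Compound 1 `Fc1ccc(-c2nn(-c3ccccc3)cc2-c2nc3cc(F)ccc3[nH]2)cc1`: > 50000 nM
Compound 2 `Fc1ccc(-c2nn(-c3ccccc3)cc2-c2nc3cc(Br)ccc3[nH]2)cc1`: 21800 nM

In an ADME assay on HaCaT cells (Homo sapiens) for cytotoxicity, read by MTT assay, with a stated time of 48 h (a lower number here means a stronger inhibitor, a higher number a weaker inhibitor), compound 1 gives > 50000 nM, which is a limit of the assay and not a number. For the measured compounds named here, compound 2 stands at 21800 nM, the only true number so far, so there is no wider series to rank it against.

Compound 3 `COc1ccc2[nH]c(-c3cn(-c4ccccc4)nc3-c3ccc(F)cc3)nc2c1` has methoxy in place of bromo on an aromatic carbon. Going by the values given here, only one measured step bears on this change: an at least 2.2-fold lower number from compound 1 to compound 2 (0.36 log units; beyond the scatter), with bromo in place of fluoro. That step is beyond the scatter but rests on a limit, and it involves no methoxy, so it is only a loose guide.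

Among the compounds with values here, compound 3 also loses the bromo, and the one compound without bromo gave the higher reading in this assay, as an at least 2.2-fold lower number from compound 1 to compound 2 (0.36 log units; beyond the scatter) shows. A small move towards a higher number is therefore expected, and it may not clear the scatter. That expectation amounts to a 1.6-fold higher number from compound 2 to compound 3 (0.21 log units; within the scatter). A reading at the limit of the assay would not be a surprise.

For compound 3 the estimated value is 35000 nM, with an expected range from 16000 nM to 70000 nM.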

Compound 3, half-maximal inhibitory concentration: > 50000 nM
Compound 3 ended at the assay's limit; the forecaster's own chance of this, stated with the estimate: 35%; at least 1.4-fold (0.15 log units) between middle value and limit.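

At this position on the shared core, the reading in this assay now looks tied to bromo rather than to any replacement of fluoro, since methoxy, a group of two heavy atoms in place of bromo's one, gives an at least 2.2-fold higher number from compound 2 to compound 3 (0.36 log units; beyond the scatter). For the compounds shown here, this is the first step that starts from the true number of compound 2 and moves away from bromo, and it is beyond the scatter, so the earlier step from fluoro to bromo no longer stands alone. Among these three compounds, only bromo brings the reading down to a measurable value, while the two other groups, fluoro and methoxy, leave it at the limit of the assay, which is a limit and not a number: the limit of > 50000 nM in this assay, at which 2 of the 3 values shown sit.

From the compounds shown here alone, the step between compound 1 and compound 3 cannot be read, as both values are limits, so fluoro and methoxy cannot be ranked against each other, and how far either lies from bromo remains unknown. Also open is whether bromo is alone in this, as the compounds shown do not say what chloro, an amine or a carboxylic acid at this position would give.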